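Dropping the 3,4-dimethoxyphenyl group: compound 2 to compound 3

The source may report more compounds than this note shows. Statements on the series, on what has been measured and on what is new or still open speak of the compounds shown alone.

Of the compounds shown here, two sharing one core have been measured so far in a functional assay on A549 cells (Homo sapiens) for inhibition, read by MTT assay, with a stated time of 72 h; a higher number here means a weaker inhibitor, a lower number a stronger inhibitor. Compound 1 `CC(C)(C)n1cc2c(n1)C(=O)CC1(CCN(C(=O)c3cc(-c4ccc(F)cc4)nc4ccccc34)CC1)O2` gives 5770 nM. Compound 2 `COc1ccc(-c2cc(C(=O)N3CCC4(CC3)CC(=O)c3nn(C(C)(C)C)cc3O4)c3ccccc3n2)cc1OC` gives 2030 nM, the lower of the two numbers and so the stronger inhibitor of this pair.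

Among the compounds with values here, the only measured step is a 2.8-fold lower number from compound 1 to compound 2 (0.45 log units; beyond the scatter), with 3,4-dimethoxyphenyl in place of 4-fluorophenyl on an aromatic carbon. It is modest but beyond the scatter.

Compound 3 `Cc1cc(C(=O)N2CCC3(CC2)CC(=O)c2nn(C(C)(C)C)cc2O3)c2ccccc2n1` has not yet been measured. It has methyl in place of 3,4-dimethoxyphenyl on an aromatic carbon, next to the ring nitrogen: methyl in place of 3,4-dimethoxyphenyl on an aromatic carbon.

The measured step bears on this only in part, since it swapped one phenyl group for another at this carbon. Within the data shown here, no measured compound lacks a phenyl group there, so the direction is uncertain. A rise in this assay of modest size is nevertheless expected, with weaker inhibition as the likelier outcome. The expected step is a 3.4-fold higher number from compound 2 to compound 3 (0.54 log units; beyond the scatter). Compound 3 is estimated at 7000 nM, with an expected range of 2500 nM to 20000 nM.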

Compound 3, half-maximal inhibitory concentration: > 10000 nM
Compound 3 ended at the assay's limit; the forecaster's own chance of this, stated with the estimate: 10%; middle value at least 1.4-fold (0.15 log units) from the limit.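

In this assay compound 3 gives > 10000 nM, which is a limit of the assay and not a number: the limit of > 10000 nM in this assay, at which 1 of the 3 values shown sits.

The earlier step only exchanged one phenyl group for another on this aromatic carbon, whereas this change removes the aromatic ring and leaves methyl, and it amounts to an at least 4.9-fold higher number from compound 2 to compound 3 (0.69 log units; beyond the scatter), so methyl does not stand in for 3,4-dimethoxyphenyl in this series. Against the 4-fluorophenyl compound the change gives an at least 1.7-fold higher number from compound 1 to compound 3 (0.23 log units; that floor lies within the scatter), and since that floor lies within the scatter, no order between these two compounds can be stated, so the loss is established only against 3,4-dimethoxyphenyl.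

On these data alone, the true size of both steps stays unknown while compound 3 remains at the limit, and the three compounds do not separate the contribution of the phenyl ring itself from that of its two methoxy groups. Open as well is how an unsubstituted phenyl, a pyridine ring, a longer alkyl chain such as propyl, or an amine would read at this carbon on the shared core.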